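The source may report more compounds than this note shows. Statements on the series, on what has been measured and on what is new or still open speak of the compounds shown alone.

Three compounds of one series were measured in a functional assay on HepG2 cells (Homo sapiens) for inhibition, read by MTT assay, with a stated time of 72 h; on this read-out higher numbers stand for weaker inhibition and lower numbers for stronger inhibition. Compound 1 `CN(C(=O)NC(=O)c1c(F)cccc1F)c1nc(C(F)(F)F)c(C(=O)N/N=C/c2cccc(C(F)(F)F)c2)s1` gives 27.9 ug/mL in this assay. Compound 2 `CN(C(=O)NC(=O)c1c(Cl)cccc1Cl)c1nc(C(F)(F)F)c(C(=O)N/N=C/c2ccccc2C(F)(F)F)s1` gives 8.95 ug/mL. Compound 3 `Cc1nc(N(C)C(=O)NC(=O)c2c(F)cccc2F)sc1C(=O)N/N=C/c1ccccc1C(F)(F)F` gives 1.11 ug/mL, the lowest of the three numbers; the nearest of the others is compound 2, whose number lies beyond the scatter above it, and compound 1 stands further away still, also beyond the scatter.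

Compound 4 `CN(C(=O)NC(=O)c1c(F)cccc1F)c1nc(C(F)(F)F)c(C(=O)N/N=C/c2ccccc2C(F)(F)F)s1` has not yet been measured. It differs from compound 3 in one place: trifluoromethyl in place of methyl on an aromatic carbon. For the measured compounds named here, compounds 1 and 2 also carry trifluoromethyl rather than methyl on the shared core, and both give higher numbers than compound 3, although each of them differs from compound 4 in a second place as well, so no single step isolates the change in question.

Since compounds 1 and 2 both stand well above compound 3, the account expects compound 4 to lose some potency against compound 3, with a step from a 4.5-fold higher number from compound 3 to compound 4 (0.65 log units; beyond the scatter) that is expected to exceed the scatter. Compound 4 is therefore estimated at 5 ug/mL in this assay, with a range from 1.5 ug/mL to 15 ug/mL, the upper end resting on compound 2, because compound 2 gives 8.95 ug/mL.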

Compound 4, half-maximal inhibitory concentration: 26.1 ug/mL
For compound 4 the middle estimate is 5.2-fold (0.72 log units) below the measured one; measured number above the stated range.
By their numbers in this assay, from the lowest: compound 3; then compound 2; then compounds 4 and 1 (each within the scatter of the next).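

In this assay the step made by trifluoromethyl in place of methyl on an aromatic carbon is a 24-fold higher number from compound 3 to compound 4 (1.37 log units; beyond the scatter) and, as the only difference between the two structures, it shows that this position of the five-membered ring responds strongly to this change. With trifluoromethyl kept at that position, 2,6-difluorophenyl in place of 2,6-dichlorophenyl on a carbonyl carbon gives only a modest step of a 2.9-fold higher number from compound 2 to compound 4 (0.46 log units; beyond the scatter) and 2-(trifluoromethyl)phenyl in place of 3-(trifluoromethyl)phenyl gives a 1.1-fold lower number from compound 1 to compound 4 (0.03 log units; within the scatter) so these two compounds cannot be told apart in this assay. Nothing available here gives a measured reason for any of these steps.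

The compounds shown carry only methyl or trifluoromethyl at this position, so it remains open how an ethyl group, a chlorine atom or an amine would stand there. Only compound 3 carries methyl, which leaves open whether the step from methyl to trifluoromethyl would keep its size alongside the 2,6-dichlorophenyl group of compound 2 or the 3-(trifluoromethyl)phenyl group of compound 1.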